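Benzyl Substitution Pattern on a Shared Nucleoside Core

A few compounds are considered here, and "the series" means these few. Any claim that something is new, unique, unknown or untested is made for them only; others in the source may bear on it.

Measured compounds:
compound 1 `OC[C@H]1O[C@@H](n2cnc3c(NCc4ccccc4F)ncnc32)[C@H](O)[C@@H]1O` — 4600 nM
compound 2 `OC[C@H]1O[C@@H](n2cnc3c(NCc4ccc(F)cc4)ncnc32)[C@H](O)[C@@H]1O` — 1250 nM
compound 3 `OC[C@H]1O[C@@H](n2cnc3c(NCc4c(F)ccc(F)c4F)ncnc32)[C@H](O)[C@@H]1O` — 90300 nM

Three compounds share one core and differ only in the fluorinated phenyl group on a saturated chain carbon bound to a nitrogen on an aromatic ring. In a functional assay on CCRF-CEM cells (Homo sapiens) for antiproliferative activity, with a stated time of 72 h (on this read-out higher numbers stand for weaker inhibition and lower numbers for stronger inhibition), compound 1 gives 4600 nM, the second highest of the three numbers. Its nearest neighbour is compound 2, reached by a 3.7-fold lower number from compound 1 to compound 2 (0.57 log units; beyond the scatter). Its furthest is compound 3, reached by a 20-fold higher number from compound 1 to compound 3 (1.29 log units; beyond the scatter); the step of a 72-fold higher number from compound 2 to compound 3 (1.86 log units; beyond the scatter) runs the same way.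

The unmeasured compound 4 `OC[C@H]1O[C@@H](n2cnc3c(NCc4ccc(F)c(Cl)c4)ncnc32)[C@H](O)[C@@H]1O` differs from compound 1 by 3-chloro-4-fluorophenyl in place of 2-fluorophenyl on a saturated chain carbon bound to a nitrogen on an aromatic ring. Among the compounds with values here, this change bears most directly on the step from compound 1 to compound 2, since the fluorine in compound 4 stands where it does in compound 2 rather than where it does in compound 1, with an added chlorine beside none of the measured patterns. Within the data shown here, compound 3 shows that stacking halogens can push the number far up, but its arrangement is not the one in compound 4. The expected step is therefore modest and downward, a 3.1-fold lower number from compound 1 to compound 4 (0.49 log units; beyond the scatter), with compound 4 estimated at 1500 nM in this assay, spanning 500 nM to 5000 nM.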

Compound 4, half-maximal inhibitory concentration: 3400 nM
Compound 4: middle estimate off by 2.3-fold (0.36 log units), on the low side; low and high end bracket the measured number.
By their numbers in this assay, from the lowest: compound 2; then compounds 4 and 1 (each within the scatter of the next); then compound 3.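

Until now every compound carried fluorine alone, and compound 4 adds a chlorine: in this assay, chloro in place of hydrogen on an aromatic carbon of the 4-fluorophenyl group costs a modest amount of inhibition (a 2.7-fold higher number from compound 2 to compound 4 (0.43 log units; beyond the scatter)). The 3-chloro-4-fluorophenyl and 2-fluorophenyl groups cannot be told apart on this read-out (a 1.4-fold lower number from compound 1 to compound 4 (0.13 log units; within the scatter)), so with the chloro group present, a fluorine placed as in compound 2 no longer keeps the number beyond the scatter from that of compound 1. Carrying more than one halogen does not by itself bring the large loss seen with the 2,3,6-trifluorophenyl group, since the change to the 3-chloro-4-fluorophenyl group recovers most of that ground (a 27-fold lower number from compound 3 to compound 4 (1.42 log units; beyond the scatter)).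

The compounds shown leave open whether a 3-chlorophenyl group without any fluorine, or a methyl or methoxy group in place of the chloro, would follow compound 4 or return to the lower number of compound 2. Nothing available explains any of these differences.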